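Halogen Swap on a Saturated Ring Carbon

This account rests on a few compounds, and the source may have more. Where it says the series, first, only, none or still open, it means among the compounds named here.

Compound 1 `O=C1NC(=O)/C(=C\c2ccc(OCC(=O)N3N=C(c4ccccc4)CC3c3ccc(Cl)c(Cl)c3)cc2)S1` was tested in an assay on cells for inhibition of histone deacetylase 8 (Homo sapiens), read by fluorescence, with a stated time of 30 min (on this read-out lower numbers stand for stronger inhibition and higher numbers for weaker inhibition), where compound 1 gives 10000 nM. Compound 2 `O=C1NC(=O)/C(=C\c2ccc(OCC(=O)N3N=C(c4ccc(F)cc4)CC3c3ccc(F)cc3F)cc2)S1` gives > 50000 nM in this assay, which is a limit of the assay rather than a number. Because compound 2 stands at the limit of > 50000 nM in this assay, at which 1 of the 2 values shown sits, its true value is not pinned down. Compound 3 `O=C1NC(=O)/C(=C\c2ccc(OCC(=O)N3N=C(c4ccc(F)cc4)CC3c3ccc(Cl)c(Cl)c3)cc2)S1` differs from compound 2 by 3,4-dichlorophenyl in place of 2,4-difluorophenyl on a saturated ring carbon. Going by the values given here, no measured pair isolates this change. The nearest comparison is compound 1, which also carries a 3,4-dichlorophenyl group and gives 10000 nM. Compound 3 is therefore expected to move toward lower numbers in this assay, a step of an at least 2.5-fold lower number from compound 2 to compound 3 (0.39 log units; beyond the scatter) whose size remains uncertain. Compound 3 is estimated at 20000 nM, with a range from 5000 nM to 60000 nM.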

Compound 3, half-maximal inhibitory concentration: 25000 nM
For compound 3 the middle estimate is 1.3-fold (0.10 log units) below the measured one, and the stated range covers the measured number.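

In this assay the exchange of 2,4-difluorophenyl for 3,4-dichlorophenyl on the saturated ring carbon can be read only as a floor, because compound 2 stands at a limit of the assay: the limit of > 50000 nM in this assay, at which 1 of the 3 values shown sits. The swap gives an at least 2.0-fold lower number from compound 2 to compound 3 (0.30 log units; that floor lies within the scatter), so this halogen change alone is not shown to matter at this place. Going by these compounds alone, with the 3,4-dichlorophenyl group kept, fluoro in place of hydrogen on an aromatic carbon gives a 2.5-fold higher number from compound 1 to compound 3 (0.40 log units; beyond the scatter), the first comparison here that isolates one change with a number at both ends.

Still open, from the compounds shown here alone, is the true size of the swap, and whether a plain phenyl or a pyridine group on the saturated ring carbon would shift the number. Going by these compounds, whether the fluoro step holds alongside a group other than 3,4-dichlorophenyl also stays open.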